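Removing the pyrazole methyl in a weak agonist series

The source may report more compounds than this note shows. Statements on the series, on what has been measured and on what is new or still open speak of the compounds shown alone.

Compound 1, `COc1cccc2c1CCC2c1ncc[nH]1`, gives 32 nM in a functional assay on CHO cells for agonist activity at Alpha-1A adrenergic receptor (Homo sapiens), read by FLIPR and calcium flux; a lower number here means that less compound is needed, a higher number that more compound is needed for the effect. Compound 2, `CS(=O)(=O)Nc1cccc2c1CCC2c1ncc[nH]1`, gives 70 nM. Compound 3, `Cn1cc(-c2cccc3c2CCC3c2ncc[nH]2)cn1`, reaches only a limit of > 2900 nM.

Compound 3 thus stands apart from the other two: its value is a limit, not a number, and it sits at the limit of > 2900 nM in this assay, at which 1 of the 3 values shown sits. The two steps that lead to it are both large and both toward higher numbers: an at least 90-fold higher number from compound 1 to compound 3 (1.95 log units; beyond the scatter) and an at least 41-fold higher number from compound 2 to compound 3 (1.61 log units; beyond the scatter). By contrast, a 2.2-fold higher number from compound 1 to compound 2 (0.34 log units; beyond the scatter) is modest. Both large steps introduce the 1-methyl-1H-pyrazol-4-yl group on the aromatic carbon, and that group stays in place in the next compound.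

Compound 4, `c1cc(-c2cn[nH]c2)c2c(c1)C(c1ncc[nH]1)CC2`, differs from compound 3 only by hydrogen in place of methyl on an aromatic nitrogen. Among the measured compounds shown here, no measured pair changes only the substituent on that ring nitrogen, so nothing here shows whether the methyl itself matters. Since compound 4 keeps the pyrazolyl group that went with the large steps to compound 3, it is expected to remain close to compound 3, and most likely again at the limit. The expected step is a step that the limit leaves unreadable from compound 3 to compound 4. Compound 4 is therefore estimated at 3000 nM, within a range of 800 nM to 12000 nM.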

Compound 4, half-maximal effective concentration: 14 nM
Compound 4: the middle estimate sits 210-fold (2.33 log units) above what was measured, and the stated range ends above it.
By their numbers in this assay, from the lowest: compound 4; then compound 1; then compound 2. At a limit, above all of these: compound 3.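

Hydrogen in place of methyl on the aromatic nitrogen changes the picture in this assay, with an at least 200-fold lower number from compound 3 to compound 4 (2.31 log units; beyond the scatter), so among these compounds the large rise seen with compound 3 goes with the methyl on that ring nitrogen and not with the pyrazole ring as such. The 1H-pyrazol-4-yl group also compares well with both earlier substituents on the aromatic carbon, with a 5.0-fold lower number from compound 2 to compound 4 (0.70 log units; beyond the scatter) and a 2.3-fold lower number from compound 1 to compound 4 (0.36 log units; beyond the scatter), both modest but beyond the scatter, which makes compound 4 the compound that needs the least for the effect among the four shown. The figure for compound 3 is a limit and not a number, so the true size of the step from it stays bounded only by that limit: the limit of > 2900 nM in this assay, at which 1 of the 4 values shown sits.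

Only methyl and hydrogen appear on that ring nitrogen here, which leaves open whether ethyl or a longer chain there would follow the methyl of compound 3 or the hydrogen of compound 4. Going by these compounds, it also remains open how an amine or a carboxylic acid on the same aromatic carbon would compare with the 1H-pyrazol-4-yl group.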